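This account rests on a few compounds, and the source may have more. Where it says the series, first, only, none or still open, it means among the compounds named here.

In a functional assay on HCC827 cells (Homo sapiens) for antiproliferative activity, read by MTT assay, with a stated time of 72 h (on this read-out lower numbers stand for stronger inhibition and higher numbers for weaker inhibition), three compounds built on a shared core have been measured. Compound 1 `CN1CCN(c2ccc(Nc3ncc4nc(Sc5ccccc5)n(C5CCOCC5)c4n3)cc2)CC1` gives 42.6 nM, compound 2 `CN1CCN(c2ccc(Nc3ncc4nc(SCc5cccnc5)n(C5CC5)c4n3)cc2)CC1` gives 8830 nM, and compound 3 `CN1CCN(c2ccc(Nc3ncc4nc(Sc5ccccc5)n(C5CC5)c4n3)cc2)CC1` gives 305 nM, the second highest of the three numbers. Compound 4 `CN1CCN(c2ccc(Nc3ncc4nc([S+]([O-])c5ccccc5)n(C5CC5)c4n3)cc2)CC1` differs from compound 3 in one place, on an aromatic carbon of a five-membered aromatic ring with 2 nitrogen: a group of 8 heavy atoms (6 carbon, 1 oxygen, 1 sulfur; one six-membered aromatic ring of carbon only) in place of a group of 7 heavy atoms (6 carbon, 1 sulfur; one six-membered aromatic ring of carbon only), on an aromatic carbon.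

Two measured steps offer a sense of scale. The closer one also concerns the group at the sulfur: phenyl in place of (pyridin-3-yl)methyl gave a 29-fold lower number from compound 2 to compound 3 (1.46 log units; beyond the scatter), a large step. The other, cyclopropyl in place of oxan-4-yl on an aromatic nitrogen, gave a 7.2-fold higher number from compound 1 to compound 3 (0.85 log units; beyond the scatter), a modest step at a different place, so it bears on this change only loosely. Neither step includes the entering group, so the direction remains uncertain. Compound 3, at 305 nM, holds the lower number of the pair changed at the sulfur, so a modest rise, meaning weaker inhibition, is the expectation. The expected change is a 2.0-fold higher number from compound 3 to compound 4 (0.29 log units; within the scatter), and a result within the scatter would be no surprise. For compound 4 the estimated value is 600 nM, with an expected range from 150 nM to 2500 nM.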

Compound 4, half-maximal inhibitory concentration: 1630 nM
Estimate against measurement, compound 4: 2.7-fold (0.43 log units) below, and the stated range covers the measured number.
By their numbers in this assay, from the lowest: compound 1; then compound 3; then compound 4; then compound 2.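

Keeping the phenyl ring and adding only an oxygen on the sulfur gives a 5.3-fold higher number from compound 3 to compound 4 (0.73 log units; beyond the scatter) in this assay, so this position responds to a change at the sulfur itself and not only to a swap of the group that the sulfur carries. The counted features do not separate the two compounds: the group that leaves and the group that enters each have the same number of hydrogen-bond donors and acceptors and no net charge, yet the read-out differs beyond the scatter. The oxygen-bearing compound also keeps part of the advantage of phenyl over (pyridin-3-yl)methyl, with a 5.4-fold lower number from compound 2 to compound 4 (0.73 log units; beyond the scatter), so adding the oxygen gives back only part of what that swap gained.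

Nothing shown here explains why the added oxygen goes with weaker inhibition. Still open, from the compounds shown here alone, are the effects of a second oxygen on the sulfur, as a sulfone, of an amine or an ether oxygen in place of the sulfur, and of the same added oxygen when oxan-4-yl replaces cyclopropyl on the ring nitrogen.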